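Swapping Benzoxazole for Benzothiazole: An Expected Gain

The source may hold more compounds than are shown below. What is called first, only, known or untested is meant among the compounds shown, and "the series" means these compounds.

Three compounds have been measured in a functional assay on A2780 cells (Homo sapiens) for cytotoxicity, read by MTT assay, with a stated time of 48 h; a lower number here means a stronger inhibitor, a higher number a weaker inhibitor:

Compound 1 `CCn1cc(-c2nc3ccccc3o2)c(=O)c2cc(F)c(N3CCNC(C)C3)c(F)c21` gives 83500 nM
Compound 2 `CCn1cc(-c2nc3ccccc3o2)c(=O)c2cc(F)c(N3CCNCC3)nc21` gives 15300 nM
Compound 3 `CCn1cc(-c2nc3ccccc3s2)c(=O)c2cc(F)c(N3CCNCC3)nc21` gives 2700 nM

Compound 1 has the highest number of the three. The difference between its core and that of compound 2 is not broken down here. Compound 2 and compound 3 share a core and differ in one place: 1,3-benzothiazol-2-yl in place of 1,3-benzoxazol-2-yl on an aromatic carbon This gave a 5.7-fold lower number from compound 2 to compound 3 (0.75 log units; beyond the scatter) in this assay.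

Compound 4 `CCn1cc(-c2nc3ccccc3s2)c(=O)c2cc(F)c(N3CCNC(C)C3)c(F)c21` is not yet measured. It differs from compound 1 in the same way: 1,3-benzothiazol-2-yl in place of 1,3-benzoxazol-2-yl on an aromatic carbon The place of the change is described in the same words for both pairs, so the change is the same. Because compound 2 to compound 3 showed a 5.7-fold lower number from compound 2 to compound 3 (0.75 log units; beyond the scatter), a similar step, a 5.6-fold lower number from compound 1 to compound 4 (0.75 log units; beyond the scatter), is expected for compound 4 in this assay. Compound 4 is therefore estimated at 15000 nM, within 5000 nM to 45000 nM.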

Compound 4, half-maximal inhibitory concentration: 9800 nM
The estimate for compound 4 lay 1.5-fold (0.18 log units) above the measured number; measured number inside the range.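

In this assay, putting 1,3-benzothiazol-2-yl in place of 1,3-benzoxazol-2-yl on the core of compound 1 gave an 8.5-fold lower number from compound 1 to compound 4 (0.93 log units; beyond the scatter), so the drop seen on the core of compound 2 appeared again. The two steps agree as closely as such measurements can show: the same change on two cores in this assay, a 5.7-fold lower number (0.75 log units; beyond the scatter) from compound 2 to compound 3 and an 8.5-fold lower number (0.93 log units; beyond the scatter) from compound 1 to compound 4, 1.5-fold (0.18 log units) apart, within the scatter of two such steps. The change therefore carried over between these two cores in this assay, but two pairs make no rule for other cores, and the numbers do not tell why sulfur in place of oxygen lowers the number.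

The compounds shown leave open whether the step survives a longer chain in place of the ethyl group. They also leave open how an amine or a carboxylic acid would compare with 1,3-benzothiazol-2-yl on the same carbon.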